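From nitro to trifluoromethyl in a series stuck at a limit

The source may report more compounds than this note shows. Statements on the series, on what has been measured and on what is new or still open speak of the compounds shown alone.

Of the compounds shown here, three that share one core have been tested in an ADME assay on Raji cells (Homo sapiens) for cytotoxicity, with a stated time of 72 h; on this read-out higher numbers stand for an effect only at larger amounts of compound and lower numbers for an effect already at smaller amounts. Compound 1 `Cc1cc(NC(=O)Nc2ccccc2N)c2ccccc2n1` reads > 25000 nM, which is a limit of the assay and not a number. Compound 2 `Cc1cc(NC(=O)Nc2cccc([N+](=O)[O-])c2)c2ccccc2n1` reads > 25000 nM, again only a limit. Compound 3 `Cc1cc(NC(=O)Nc2ccc(O)cc2)c2ccccc2n1` reads > 25000 nM, also a limit. Compound 2 therefore has no exact place among the three, and the whole set rests on (the limit of > 25000 nM in this assay, at which 3 of the 3 values shown sit).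

Compound 4 `Cc1cc(NC(=O)Nc2cccc(C(F)(F)F)c2)c2ccccc2n1` differs from compound 2 in one place: trifluoromethyl in place of nitro on an aromatic carbon. Trifluoromethyl takes the place of nitro on an aromatic carbon, meta to a large group.

Going by the values given here, the only measured step of a single change is a step that the two limits leave unreadable from compound 1 to compound 3. It puts 4-hydroxyphenyl in place of 2-aminophenyl on an amide-type nitrogen, and it offers no size to carry over to the new change. With nothing readable to build on, no step beyond the scatter is expected in this assay, in either direction, and another limit is the likeliest report. The expected step is a number no higher from compound 2 to compound 4 (the limit leaves the size open). For compound 4 the estimated value is 25000 nM, with an expected range from 10000 nM to 50000 nM.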

Compound 4, half-maximal effective concentration: 10000 nM
Compound 4: the middle estimate sits 2.5-fold (0.40 log units) above what was measured; the measured number falls inside the stated range.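

In this assay, going by these compounds alone, trifluoromethyl in place of nitro on an aromatic carbon, meta to a large group, gives an at least 2.5-fold lower number from compound 2 to compound 4 (0.39 log units; beyond the scatter), the first step in this set with a readable direction. It shows that this one position can move the read-out away from the limit, so the series is not fixed there whatever sits on the ring, although this rests on a single pair of compounds. Compound 2 reads > 25000 nM, which is a limit of the assay and not a number, and the true gap can only be given as a minimum because of that limit: the limit of > 25000 nM in this assay, at which 3 of the 4 values shown sit.

The compounds shown leave open whether a chlorine atom, a methyl group or a nitrile at the same carbon would also lower the number, and so whether trifluoromethyl is special or nitro is the exception. They also leave open whether trifluoromethyl on a different carbon of that ring would give the same step, and how far the true value of compound 2 lies from that of compound 4.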